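Chain extension tested across two agonist cores

The compounds below may be only part of what the source reports. "The series", "measured", "known", "first", "only" and "open" are said of these compounds alone.

Measured so far in a functional assay for agonist activity at follicle-stimulating hormone receptor (Homo sapiens), read by a luciferase reporter; on this read-out higher numbers stand for an effect only at larger amounts of compound and lower numbers for an effect already at smaller amounts:
compound 1 `CCCCCCCN1CC(=O)N(C)[C@@H](Cc2ccc(-c3cc(OC)c(OC)c(OC)c3)cc2)C1=O` gives 2300 nM
compound 2 `CCCCCN1CC(=O)N(C)[C@@H](Cc2ccc(-c3cc(OC)c(OC)c(OC)c3)cc2)C1=O` gives 9000 nM
compound 3 `CCCCCCN1C(=O)[C@H](Cc2ccc(-c3cccc(CN(CCCC)C(=O)OC)c3)cc2)N(C)C(=O)[C@@H]1C` gives 8.9 nM

Compounds 1 and 2 share one core and differ only by ethyl in place of hydrogen on a saturated chain carbon, five bonds along the chain from an amide-type nitrogen in a ring; this gives a 3.9-fold lower number from compound 2 to compound 1 (0.59 log units; beyond the scatter). Compound 3 stands on a different core, and how it differs from compound 2 is not broken down here. Within the set compound 3 has the lowest number, with compound 1 nearest and compound 2 furthest.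

Compound 4 `CCCCCCCCN1C(=O)[C@H](Cc2ccc(-c3cccc(CN(CCCC)C(=O)OC)c3)cc2)N(C)C(=O)[C@@H]1C` is not yet measured. It differs from compound 3 by ethyl in place of hydrogen on a saturated chain carbon, six bonds along the chain from an amide-type nitrogen in a ring. This is the same kind of change as that from compound 2 to compound 1, not the same: the place is five bonds along the chain from an amide-type nitrogen in a ring in the first pair and six bonds along the chain from an amide-type nitrogen in a ring in the second, and the cores are not the same. Compound 4 is expected to move in the same direction, but a smaller step is estimated, a 2.0-fold lower number from compound 3 to compound 4 (0.30 log units; within the scatter), since compound 3 already gives 8.9 nM on a core where this change has not been tested. Compound 4 is estimated at 4.5 nM, between 1.5 nM and 15 nM.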

Compound 4, half-maximal effective concentration: 2.7 nM
Beside the measured number, compound 4's estimate is 1.7-fold (0.22 log units) above it, and the stated range covers the measured number.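

In this assay, putting ethyl in place of hydrogen on the chain gives a 3.3-fold lower number from compound 3 to compound 4 (0.52 log units; beyond the scatter), and the step matches the one seen on the other core: the same change on two cores in this assay, a 3.9-fold lower number (0.59 log units; beyond the scatter) from compound 2 to compound 1 and a 3.3-fold lower number (0.52 log units; beyond the scatter) from compound 3 to compound 4, 1.2-fold (0.07 log units) apart, within the scatter of two such steps

Within these two pairs, the change therefore carries from one core to the other in both direction and size, even though the two cores give very different numbers and the place of the change is not the same. This does not show a general rule for the series, since it rests on one pair per core and a single chain extension on each, and it gives no reason why the numbers fall.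

As far as these compounds go, it remains open whether a longer chain than that of compound 4 lowers the number further on the core of compound 3 or whether the trend stops there. Also open, from the compounds shown here alone, is whether a chain carrying a hydroxyl group or an amine would fit the same trend on either core.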